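Swapping a spiro diamine for a methylurea pyrrolidine

The source may report more compounds than this note shows. Statements on the series, on what has been measured and on what is new or still open speak of the compounds shown alone.

Measured so far:
Compound 1 `Nc1ccc2cc(NC(=O)CCc3ccc(C(F)(F)F)cc3)ccc2n1` gives 720 nM in a functional assay on HEK293 cells for activation of melanin-concentrating hormone receptor 1 (Rattus norvegicus), read by inositol phosphate accumulation; on this read-out higher numbers stand for an effect only at larger amounts of compound and lower numbers for an effect already at smaller amounts.
Compound 2 `CC(=O)NC1CCN(c2ccc3cc(NC(=O)CCc4ccc(C(F)(F)F)cc4)ccc3n2)C1` gives 440 nM in this assay.
Compound 3 `O=C(CCc1ccc(C(F)(F)F)cc1)Nc1ccc2nc(N3CCC4(CCNC4)C3)ccc2c1` gives 140 nM in this assay.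

Compound 3 stands lowest of the three numbers. Its nearest neighbour is compound 2, with a 3.1-fold lower number from compound 2 to compound 3 (0.50 log units; beyond the scatter); furthest is compound 1, with a 5.1-fold lower number from compound 1 to compound 3 (0.71 log units; beyond the scatter).

The next compound is compound 4 `CNC(=O)NC1CCN(c2ccc3cc(NC(=O)CCc4ccc(C(F)(F)F)cc4)ccc3n2)C1`. Its difference from compound 3 is a group of 10 heavy atoms (6 carbon, 3 nitrogen, 1 oxygen; one five-membered non-aromatic ring with 1 hetero atom) in place of a group of 9 heavy atoms (7 carbon, 2 nitrogen; 2 five-membered non-aromatic rings with 1 hetero atom each), on an aromatic carbon. In effect, compound 4 carries a ring of the same kind as compound 2, with a methylurea where compound 2 carries an acetamide.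

Among the compounds with values here, two measured steps bear on this change. The step of a 1.6-fold lower number from compound 1 to compound 2 (0.21 log units; within the scatter) shows that putting the acetamido-pyrrolidine onto the core changed the number little. The step of a 3.1-fold lower number from compound 2 to compound 3 (0.50 log units; beyond the scatter) shows that exchanging that ring for the spiro diamine brought a modest gain. Compound 4 undoes that second exchange while keeping a closely related ring, so a modest rise in the number is expected, roughly the reverse of the step seen between compound 2 and compound 3. The expected step is a 2.9-fold higher number from compound 3 to compound 4 (0.46 log units; beyond the scatter). Compound 4 is therefore estimated at 400 nM, with a range from 150 nM to 1100 nM.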

Compound 4, half-maximal effective concentration: 30 nM
For compound 4 the middle estimate is 13-fold (1.12 log units) above the measured one; measured number below the stated range.
By their numbers in this assay, from the lowest: compound 4; then compound 3; then compounds 2 and 1 (each within the scatter of the next).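

The clearest finding comes from the smallest change. In this assay, methylamino in place of methyl on the carbonyl carbon, which turns the acetamide into a methylurea, gives a 15-fold lower number from compound 2 to compound 4 (1.17 log units; beyond the scatter) and so shows that the far end of this substituent can matter much more than a 1.6-fold lower number from compound 1 to compound 2 (0.21 log units; within the scatter) alone suggested. With that end changed, the 3-((methylcarbamoyl)amino)pyrrolidin-1-yl group on the aromatic carbon next to the ring nitrogen gives a 24-fold lower number from compound 1 to compound 4 (1.38 log units; beyond the scatter) against plain amino, and a 4.7-fold lower number from compound 3 to compound 4 (0.67 log units; beyond the scatter) shows that a substituent with one non-aromatic ring can give a lower number here than the spiro diamine with two. No measurement shown explains why swapping one small group has so large an effect.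

From the compounds shown here alone, what an ethylurea or a methyl carbamate would do in place of the methylurea remains open. Going by these compounds, it is also open whether the methylurea would give a similarly large step on a piperidine ring, or whether the pyrrolidine ring is needed at all.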